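The source may report more compounds than this note shows. Statements on the series, on what has been measured and on what is new or still open speak of the compounds shown alone.

Measured so far:
compound 1, `CC(NC(=O)NS(=O)(=O)c1ccc(Cl)cc1)c1ccccc1OCc1ccccc1`, gives 157000 nM in a functional assay on thoracic aorta (Rattus norvegicus, strain Wistar), with a stated time of 15 min; a higher number here means that more compound is needed for the effect, a lower number that less compound is needed.
compound 2, `Cc1ccc(S(=O)(=O)N(C)C(=O)NC(C)c2cc(C)ccc2OCc2ccccc2)cc1`, gives 181000 nM in this assay.
compound 3, `CC(NC(=O)N(C)S(=O)(=O)c1ccc(Cl)cc1)c1ccccc1OCc1ccccc1`, gives 38400 nM in this assay.

The three compounds share a chain that runs from a sulfonyl group through a urea-type linkage to a benzylic carbon bearing a phenyl ring. Compound 3 carries a methyl on the nitrogen between the carbonyl and the sulfonyl group; compound 1 has a hydrogen there instead. That one change, (hydrogen in place of methyl on an amide-type nitrogen), gave a 4.1-fold higher number from compound 3 to compound 1 (0.61 log units; beyond the scatter). Compound 2 stands close to compound 1, with a gap that is within the scatter, and well above compound 3.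

Compound 4, `Cc1ccc(S(=O)(=O)NC(=O)NC(C)c2cc(C)ccc2OCc2ccccc2)cc1`, has not yet been measured. It is derived from compound 2 by hydrogen in place of methyl on an amide-type nitrogen, the same change that was made from compound 3 to compound 1; the place is described in the same words in both cases. How the core of compound 2 differs from the core of compound 3 is not broken down here.

If the change behaves as it did before, the number for compound 4 in this assay is expected to rise, with an estimated step of a 2.8-fold higher number from compound 2 to compound 4 (0.44 log units; beyond the scatter), resting on compound 3 to compound 1 having shown a 4.1-fold higher number from compound 3 to compound 1 (0.61 log units; beyond the scatter). Compound 4 is therefore expected to give about 500000 nM, most likely between 150000 nM and 1500000 nM.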

Compound 4, half-maximal effective concentration: 91900 nM
Beside the measured number, compound 4's estimate is 5.4-fold (0.74 log units) above it; measured number below the stated range.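

On the core of compound 2, the swap of methyl for hydrogen on the amide-type nitrogen does not repeat the earlier rise: in this assay it gives a 2.0-fold lower number from compound 2 to compound 4 (0.29 log units; within the scatter). Removing this methyl therefore cannot be treated as a step of fixed size that transfers from one core to another in this series, and even its direction is not secure, as the two results differ by more than normal measurement variation: the same change on two cores in this assay, a 4.1-fold higher number (0.61 log units; beyond the scatter) from compound 3 to compound 1 and a 2.0-fold lower number (0.29 log units; within the scatter) from compound 2 to compound 4, 8.1-fold (0.91 log units) apart, beyond the scatter of two such steps

This does not show which feature of the two cores separates the results, or which result is more typical of the series, as two pairs are too few to settle either point.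

The compounds shown leave open how the number would respond to an ethyl group or a longer chain on this amide-type nitrogen, since only methyl and hydrogen appear there. They also leave open which individual difference between the two cores matters. Among the compounds shown here, no pair here isolates a single one of those differences with the methyl and the hydrogen each tested on both sides.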